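Aryl swap on the second exocyclic arm, compound 3

The source may hold more compounds than are shown below. What is called first, only, known or untested is meant among the compounds shown, and "the series" means these compounds.

Within the data shown here, compound 2 `C=CCn1c(=O)/c(=C\c2ccccc2C(F)(F)F)[nH]c(=O)/c1=C\c1ccccc1OC` carries the lowest number so far in a functional assay on HeLa cells (Homo sapiens) for cytotoxicity, read by CCK-8 assay, with a stated time of 72 h (a lower number here means a stronger inhibitor, a higher number a weaker inhibitor), where compound 2 gives 4600 nM. Among the measured compounds shown here, the only comparator is compound 1 `C=CCn1c(=O)/c(=C\c2cc(Br)ccc2F)[nH]c(=O)/c1=C\c1ccccc1OC`, which in this assay gives 34600 nM; the step of a 7.5-fold lower number from compound 1 to compound 2 (0.88 log units; beyond the scatter) shows that the aryl group on this arm moves the read-out well beyond the scatter. Compound 3 `C=CCn1c(=O)/c(=C\c2cccc(C)c2)[nH]c(=O)/c1=C\c1ccccc1OC` is not yet measured; it differs from compound 2 by 3-methylphenyl in place of 2-(trifluoromethyl)phenyl on a double-bonded chain carbon bound to an aromatic carbon. That single step is the only one bearing on this position, and it exchanged one halogen-bearing ring for a trifluoromethyl-bearing one, so it does not fix the direction for a methyl-bearing ring. A change of modest size in this assay is expected, more likely toward a higher number, and for compound 3 it is estimated as a 2.2-fold higher number from compound 2 to compound 3 (0.34 log units; beyond the scatter). Compound 3 is estimated at 10000 nM in this assay, within 3000 nM to 35000 nM.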

Compound 3, half-maximal inhibitory concentration: 19300 nM
For compound 3 the middle estimate is 1.9-fold (0.29 log units) below the measured one; low and high end bracket the measured number.
By their numbers in this assay, from the lowest: compound 2; then compounds 3 and 1 (each within the scatter of the next).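

In this assay, a 4.2-fold higher number from compound 2 to compound 3 (0.62 log units; beyond the scatter) shows that the low number of compound 2 does not carry over to every aryl group at this position, even though 2-(trifluoromethyl)phenyl and 3-methylphenyl each hold one six-membered aromatic ring of carbon only and no hydrogen-bond donors or acceptors. The other new step, a 1.8-fold lower number from compound 1 to compound 3 (0.25 log units; within the scatter), lies within the scatter, so 3-methylphenyl and 5-bromo-2-fluorophenyl cannot be told apart in this read-out. Among the three compounds, only compound 2 stands apart from both others beyond the scatter.

Still open, from the compounds shown here alone, is whether the number of compound 2 follows the trifluoromethyl group itself or its ring location, since the step to compound 3 changes both, and how an aryl ring bearing an amine or a carboxylic acid would read. No measurement at hand explains the differences at this position.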